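Chloro in place of bromo in the 2-bromophenyl amide

The compounds below may be only part of what the source reports. "The series", "measured", "known", "first", "only" and "open" are said of these compounds alone.

In a functional assay on SK-BR-3 cells (Homo sapiens) for antiproliferative activity, read by MTT assay, with a stated time of 72 h (a lower number here means a stronger inhibitor, a higher number a weaker inhibitor), compound 1 `CCN1CCN(c2cc(C)c3cc(NC(=O)c4ccc(C)cc4)ccc3n2)CC1` gives 11400 nM and compound 2 `CCN1CCN(c2cc(C)c3cc(NC(=O)c4cccnc4)ccc3n2)CC1` gives 10600 nM. These two do not separate: a 1.1-fold lower number from compound 1 to compound 2 (0.03 log units; within the scatter). Compound 3 `CCN1CCN(c2cc(C)c3cc(NC(=O)c4ccccc4Br)ccc3n2)CC1`, at 39200 nM, has the highest number of the three. Moving to its 2-bromophenyl group gives a 3.4-fold higher number from compound 1 to compound 3 (0.54 log units; beyond the scatter), and likewise a 3.7-fold higher number from compound 2 to compound 3 (0.57 log units; beyond the scatter).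

Compound 4 `CCN1CCN(c2cc(C)c3cc(NC(=O)c4ccccc4Cl)ccc3n2)CC1` carries 2-chlorophenyl instead: chloro in place of bromo on an aromatic carbon. The new group sits on an aromatic carbon, ortho to a large group, as the bromo did. Among the measured compounds shown here, both steps into compound 3 exchange a whole group on the carbonyl carbon, and no measured step exchanges bromo for chloro, so their size cannot be carried over directly. The expectation rests on compound 3 at 39200 nM, which differs from compound 4 at this one atom only. No step beyond the scatter is expected in this assay, with a slight lean toward lower numbers. The estimated step is a 1.4-fold lower number from compound 3 to compound 4 (0.15 log units; within the scatter). For compound 4 the estimated value is 28000 nM, with an expected range from 12000 nM to 60000 nM.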

Compound 4, half-maximal inhibitory concentration: > 50000 nM
Compound 4 gave a limit, no number; the forecaster's own chance of this, stated with the estimate: 8%; middle value at least 1.7-fold (0.25 log units) away from the limit.
By their numbers in this assay, from the lowest: compounds 2 and 1 (each within the scatter of the next); then compound 3. At a limit, above all of these: compound 4.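

In this assay compound 4 gives a limit and not a number: the limit of > 50000 nM in this assay, at which 1 of the 4 values shown sits. Chloro in place of bromo on an aromatic carbon, ortho to a large group, is the only step here that exchanges a single atom, and it reads as an at least 1.2-fold higher number from compound 3 to compound 4 (0.10 log units; that floor lies within the scatter), so this floor does not set the two halogens apart. The 2-chlorophenyl group stays on the high side, as the 2-bromophenyl group did, with an at least 4.7-fold higher number from compound 2 to compound 4 (0.67 log units; beyond the scatter) and an at least 4.3-fold higher number from compound 1 to compound 4 (0.64 log units; beyond the scatter).

The limit leaves the full size of all three steps unread. From the compounds shown here alone, whether a halogen is needed for these higher numbers remains open, and the 2-methylphenyl or 2-methoxyphenyl amide on the shared core would test that.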